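This account rests on a few compounds, and the source may have more. Where it says the series, first, only, none or still open, it means among the compounds named here.

Measured compounds in the series:
- compound 1, `CC1=C(/C=C/C(=O)/C=C/c2ccc(F)cc2)C(C)(C)CCC1`: in a functional assay on Hep cells (Homo sapiens) for cytotoxicity, read by sulforhodamine B assay, with a stated time of 48 h (a lower number here means a stronger inhibitor, a higher number a weaker inhibitor), compound 1 gives 55800 nM
- compound 2, `CC1=C(/C=C/C(=O)/C=C/c2cccnc2)C(C)(C)CCC1`: in this assay compound 2 gives 45600 nM

Among the measured compounds shown here, compound 2 holds the lowest of the two numbers in this assay; its nearest neighbour is compound 1, and the only known step, a 1.2-fold lower number from compound 1 to compound 2 (0.09 log units; within the scatter), stays within the scatter, so the two compounds are not separated by this assay.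

Compound 3, `CC1=C(/C=C/C(=O)/C=C/c2ccoc2)C(C)(C)CCC1`, has not yet been run in this assay. It differs from compound 2 by furan-3-yl in place of pyridin-3-yl on a double-bonded chain carbon bound to a double-bonded chain carbon. For the measured compounds named here, the one step that bears on this exchange is a 1.2-fold lower number from compound 1 to compound 2 (0.09 log units; within the scatter), in which a change of the aryl group at the same place gave no movement beyond the scatter. Going by the values given here, no measured step shows a five-membered ring at this place. On that basis the step for compound 3 is expected to be a 1.1-fold higher number from compound 2 to compound 3 (0.04 log units; within the scatter), that is, no change beyond the scatter. Compound 3 is therefore estimated at 50000 nM in this assay, with a range of 20000 nM to 125000 nM.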

Compound 3, half-maximal inhibitory concentration: > 100000 nM
Compound 3: no number, only a limit; the forecaster's own chance of this, stated with the estimate: 15%; at least 2.0-fold (0.30 log units) between middle value and limit.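

In this assay compound 3 gives no number, only a limit: the limit of > 100000 nM in this assay, at which 1 of the 3 values shown sits. Among the compounds shown here, the exchange of pyridin-3-yl for furan-3-yl gives an at least 2.1-fold higher number from compound 2 to compound 3 (0.34 log units; beyond the scatter) and is the first movement beyond the scatter at this place, where the earlier exchange of 4-fluorophenyl for pyridin-3-yl gave none, so the group on this double-bonded chain carbon can alter the read-out. The exchange of 4-fluorophenyl for furan-3-yl gives an at least 1.7-fold higher number from compound 1 to compound 3 (0.25 log units; that floor lies within the scatter) and so leaves that comparison unresolved.

Going by these compounds, how far compound 3 lies past its limit remains open, as does whether the shift belongs to furan-3-yl alone or to five-membered aromatic rings at this place in general. Also open, on these data alone, is how thiophen-3-yl, or a phenyl group carrying an amine or a carboxylic acid, would read in this assay at this place.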